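This account rests on a few compounds, and the source may have more. Where it says the series, first, only, none or still open, it means among the compounds named here.

Measured in an ADME assay on HEK-293T cells (Homo sapiens) for cytotoxicity, read by CCK-8 assay, with a stated time of 48 h; a higher number here means a weaker inhibitor, a lower number a stronger inhibitor:
- compound 1 `COc1ccc(Oc2ccccc2-c2ccsc2S(=O)(=O)NCCNC(=S)Nc2cc(C(F)(F)F)cc(C(F)(F)F)c2)cc1OC`: 6800 nM
- compound 2 `O=S(=O)(NCCNC(=S)Nc1cc(C(F)(F)F)cc(C(F)(F)F)c1)c1sccc1-c1ccccc1Oc1ccc(O)c(O)c1`: 7500 nM

Only these two compounds have been measured so far, so compound 2 can be placed only against compound 1, and their values lie within the scatter of each other. The next compound, compound 3 `Cc1ccc(-c2ccsc2S(=O)(=O)NCCNC(=S)Nc2cc(C(F)(F)F)cc(C(F)(F)F)c2)c(Oc2ccc(O)c(O)c2)c1`, changes compound 2 in one place: methyl in place of hydrogen on an aromatic carbon. For the measured compounds named here, only one measured step is available for comparison, a 1.1-fold higher number from compound 1 to compound 2 (0.04 log units; within the scatter). It put 3,4-dihydroxyphenyl in place of 3,4-dimethoxyphenyl, which is a different change from this one, so it bears on the new step only indirectly. Going by the values given here, no measured step shows what a methyl does here, so no direction can be argued from the data. The expected change is a 1.1-fold lower number from compound 2 to compound 3 (0.03 log units; within the scatter), which means no step beyond the scatter. Compound 3 is estimated at 7000 nM, with an expected range of 3500 nM to 14000 nM.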

Compound 3, half-maximal inhibitory concentration: 8000 nM
For compound 3 the middle estimate is 1.1-fold (0.06 log units) below the measured one; the measured number falls inside the stated range.
By their numbers in this assay, from the lowest: compounds 1, 2 and 3 (each within the scatter of the next).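

In this assay, a methyl in place of hydrogen on this aromatic carbon, meta to a 3,4-dihydroxyphenoxy group and para to a large group, gives a 1.1-fold higher number from compound 2 to compound 3 (0.03 log units; within the scatter), so the two compounds cannot be told apart here. For the compounds shown here, the earlier pair varied only the 3,4-dihydroxyphenyl and 3,4-dimethoxyphenyl groups, so this is the first reading of a change on this six-membered aromatic ring, and one added carbon at this position produces no step beyond the scatter. Nothing measured here offers an explanation for this reading.

On these data alone, whether a different group on the same carbon, such as a chlorine atom, a methoxy group or an amine, would also stay within the scatter remains open. One methyl at one position also cannot show how the other carbons of this ring would respond.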